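A few compounds are considered here, and "the series" means these few. Any claim that something is new, unique, unknown or untested is made for them only; others in the source may bear on it.

In a physicochemical assay for solubility (a lower number here means a less soluble compound, a higher number a more soluble compound), compound 2 `CNC(=O)c1cc(C(=O)NC2CC2)cn(CC2CCCCC2)c1=O` gives >= 148 ug/mL, which is a limit of the assay and not a number. Compound 1 `CNC(=O)c1cc(C(=O)NC2CC2)cn([C@H](C)c2ccccc2)c1=O` gives >= 168 ug/mL, also a limit. Within the data shown here, the only measured step that bears on the change, a step that the two limits leave unreadable from compound 1 to compound 2, therefore has no readable size. Compound 3 `CNC(=O)c1cc(C(=O)NC2CC2)cn(Cc2cccc(OC)c2)c1=O` has 3-methoxyphenyl in place of cyclohexyl on a saturated chain carbon bound to an aromatic nitrogen. With no readable size to build on, no change beyond the scatter is expected, and the expected step is a step that the limit leaves unreadable from compound 2 to compound 3. For compound 3 the estimate is 165 ug/mL, with an expected range of 100 ug/mL to 185 ug/mL.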

Compound 3, solubility: 79 ug/mL
For compound 3 the middle estimate is 2.1-fold (0.32 log units) above the measured one; measured number outside the range, below it.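

In this assay, among these compounds, compound 3 gives the first value that is a number and not a limit, so a group on a saturated chain carbon bound to an aromatic nitrogen can leave a readable number. Putting 3-methoxyphenyl in place of cyclohexyl gives an at least 1.8-fold lower number from compound 2 to compound 3 (0.27 log units; that floor lies within the scatter), so the true change may be larger, but its readable part does not go beyond the scatter. Only this floor can be given because compound 2 stands at a limit of the assay: the limit of >= 148 ug/mL in this assay, at which 1 of the 3 values shown sits.

The step from compound 1 to compound 2 cannot be read. Going by these compounds, whether the lower number goes with the aromatic ring or with its methoxy stays open, and a plain phenyl group at this place would help separate the two.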